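The compounds below may be only part of what the source reports. "The series", "measured", "known", "first", "only" and "open" are said of these compounds alone.

Measured so far in a functional assay on HCT-116 cells (Homo sapiens) for antiproliferative activity, read by sulforhodamine B assay, with a stated time of 72 h; on this read-out lower numbers stand for stronger inhibition and higher numbers for weaker inhibition:
- compound 1 `CNC(=O)C[C@@H]1C[C@@H](c2ccc(Cl)c(Cl)c2)[C@H](NC(=O)c2cc(-c3c(Cl)cnn3C)c(Cl)o2)CN1`: 450 nM
- compound 2 `Cn1ncc(Cl)c1-c1cc(C(=O)N[C@@H]2CN[C@H](CC(=O)O)C[C@H]2c2ccc(Cl)c(Cl)c2)oc1Cl`: 4020 nM
- compound 3 `CNC(=O)C[C@@H]1C[C@@H](c2ccc(F)c(F)c2)[C@H](NC(=O)c2cc(-c3c(Cl)cnn3C)c(Cl)o2)CN1`: 1100 nM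

Compound 2, at 4020 nM, carries the highest number of the three. Compound 4 `Cn1ncc(Cl)c1-c1cc(C(=O)N[C@@H]2CN[C@H](CCN3CCCC3)C[C@H]2c2ccc(Cl)c(Cl)c2)oc1Cl` departs from it in a single place: (pyrrolidin-1-yl)methyl in place of carboxy on a saturated chain carbon bound to a saturated ring carbon. In words, this is (pyrrolidin-1-yl)methyl in place of carboxy on a saturated chain carbon bound to a saturated ring carbon.

Two measured steps are available. The more relevant is an 8.9-fold higher number from compound 1 to compound 2 (0.95 log units; beyond the scatter), the step in which hydroxy replaced methylamino on a carbonyl carbon and so produced the carboxy group that compound 4 no longer has. The other, a 2.4-fold higher number from compound 1 to compound 3 (0.39 log units; beyond the scatter), exchanged 3,4-dichlorophenyl for 3,4-difluorophenyl, a change that plays no part here, since compound 2 and compound 4 share the 3,4-dichlorophenyl group. Among the measured compounds shown here, no measured compound carries a pyrrolidine, so the size of the move remains uncertain.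

In this assay, a move towards a lower number is therefore expected, of roughly the size seen between the first two compounds, though in the opposite direction. The expected change is an 8.0-fold lower number from compound 2 to compound 4 (0.91 log units; beyond the scatter). For compound 4 the estimated value is 500 nM, with an expected range from 150 nM to 1600 nM.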

Compound 4, half-maximal inhibitory concentration: 1940 nM
For compound 4 the middle estimate is 3.9-fold (0.59 log units) below the measured one, outside the stated range (above it).
By their numbers in this assay, from the lowest: compound 1; then compounds 3 and 4 (each within the scatter of the next); then compound 2.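

In this assay the position on a saturated chain carbon bound to a saturated ring carbon now has three groups to compare with the 3,4-dichlorophenyl group held constant, and the change from carboxy to (pyrrolidin-1-yl)methyl gives a 2.1-fold lower number from compound 2 to compound 4 (0.32 log units; beyond the scatter). Methylcarbamoyl still gives the lowest number of the three, since its replacement by (pyrrolidin-1-yl)methyl gives a 4.3-fold higher number from compound 1 to compound 4 (0.63 log units; beyond the scatter), so this change recovers only part of the loss seen in an 8.9-fold higher number from compound 1 to compound 2 (0.95 log units; beyond the scatter). Nothing shown here explains this order of the three groups.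

The compounds shown leave open whether the gap between methylcarbamoyl and (pyrrolidin-1-yl)methyl follows the loss of the amide or the arrival of the ring, a question that a pyrrolidin-1-ylcarbonyl group or a dimethylaminomethyl group at this position could help to separate. They also leave open whether the same order of groups holds with the 3,4-difluorophenyl group in place of 3,4-dichlorophenyl, as only the methylcarbamoyl compound carries it here.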